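The source may hold more compounds than are shown below. What is called first, only, known or untested is meant among the compounds shown, and "the series" means these compounds.

Compound 1 `COc1ccc2occ(CSC(=S)N(C(C)C)C(C)C)c(=O)c2c1` gives the lowest number of the three measured in a functional assay on LM7 cells (Homo sapiens) for antiproliferative activity, read by MTT assay, with a stated time of 72 h (on this read-out lower numbers stand for stronger inhibition and higher numbers for weaker inhibition), at 4700 nM. Compound 2 `COc1ccc2oc(CSC(=S)N3CCOCC3)cc(=O)c2c1` gives 11000 nM in this assay, and compound 3 `CC(C)N(C(=S)SCc1coc2ccccc2c1=O)C(C)C` gives 21900 nM. Among the measured compounds shown here, the only step between compounds that differ in one place, hydrogen in place of methoxy on an aromatic carbon, is a 4.7-fold higher number from compound 1 to compound 3 (0.67 log units; beyond the scatter). Compound 4 `COc1ccc2occ(CSC(=S)N3CCCCC3)c(=O)c2c1` differs from compound 1 by piperidin-1-yl in place of diisopropylamino on a thiocarbonyl carbon. For the measured compounds named here, no measured step concerns a change on the thiocarbonyl carbon; compound 2 carries a ring amine there but differs from compound 1 in a second place as well, so its value alone settles little. A step within the scatter, or slightly toward a higher number, is therefore expected, a 1.3-fold higher number from compound 1 to compound 4 (0.11 log units; within the scatter). Compound 4 is estimated at 6000 nM, expected between 2500 nM and 15000 nM.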

Compound 4, half-maximal inhibitory concentration: 4700 nM
Estimate against measurement, compound 4: 1.3-fold (0.11 log units) above; measured number inside the range.
By their numbers in this assay, from the lowest: compounds 1 and 4 (each within the scatter of the next); then compounds 2 and 3 (each within the scatter of the next).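

In this assay the change on the thiocarbonyl carbon can now be read alone: piperidin-1-yl in place of diisopropylamino gives no change at the digits printed from compound 1 to compound 4 (within the scatter) in this core. At this position, therefore, an open-chain amine and a six-membered non-aromatic ring give the same number for compound 1 and compound 4. Nothing measured here offers an explanation for this result.

Left open is whether dimethylamino or piperazin-1-yl on the same carbon would also keep the number. Also open, from the compounds shown here alone, is whether removing methoxy from compound 4 would raise its number as it did for compound 1.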